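Swapping the Side Group, Watching Liver Cell Tolerance

This account rests on a few compounds, and the source may have more. Where it says the series, first, only, none or still open, it means among the compounds named here.

Compound 2 `O=C1CNC(=O)N1C[C@H]1CN(c2ccc(-n3cc(-c4ccccn4)cn3)c(F)c2)C(=O)O1` carries a 2,5-dioxoimidazolidin-1-yl group on a saturated chain carbon bound to a saturated ring carbon. In an ADME assay on L02 cells (Homo sapiens) for cytotoxicity, read by MTT assay, with a stated time of 48 h (a lower number here means a stronger inhibitor, a higher number a weaker inhibitor), compound 2 gives > 400 ug/mL, which is a limit of the assay rather than a measured number. Its two neighbours share the same core. Compound 1 `O=C1CCC(=O)N1C[C@H]1CN(c2ccc(-n3cc(-c4ccccn4)cn3)c(F)c2)C(=O)O1` bears 2,5-dioxopyrrolidin-1-yl at that place, and in this assay compound 1 gives > 400 ug/mL, again a limit. Compound 3 `O=CNC[C@H]1CN(c2ccc(-n3cc(-c4ccccn4)cn3)c(F)c2)C(=O)O1` bears formylamino there, and in this assay compound 3 gives > 400 ug/mL, also a limit. The steps among them are therefore a step that the two limits leave unreadable from compound 1 to compound 2, a step that the two limits leave unreadable from compound 1 to compound 3 and a step that the two limits leave unreadable from compound 2 to compound 3: all three values rest at the limit of > 400 ug/mL in this assay, at which 3 of the 3 values shown sit, so none of these steps can be sized.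

Compound 4 `COC(=O)NC[C@H]1CN(c2ccc(-n3cc(-c4ccccn4)cn3)c(F)c2)C(=O)O1` is the next member of the set: (methoxycarbonyl)amino in place of 2,5-dioxoimidazolidin-1-yl on a saturated chain carbon bound to a saturated ring carbon. The measured steps that vary the same place bear on it, but because of the limit of > 400 ug/mL in this assay, at which 3 of the 3 values shown sit, they show only that every variation tried so far stayed at the limit. No step beyond the scatter is expected in this assay. The step is estimated as a number no higher from compound 2 to compound 4 (the limit leaves the size open). Compound 4 is expected to give about 400 ug/mL, with a range from 200 ug/mL to 800 ug/mL.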

Compound 4, half-maximal inhibitory concentration: 71 ug/mL
The estimate for compound 4 lay 5.6-fold (0.75 log units) above the measured number, and the stated range ends above it.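

Going by these compounds alone, compound 4 is the first compound here to give a real number in this assay, which shows that the group at this place, on a saturated chain carbon bound to a saturated ring carbon, can shift the reading towards a stronger inhibitor. Measured against the two groups that hold a ring, the change reads as an at least 5.6-fold lower number from compound 2 to compound 4 (0.75 log units; beyond the scatter) and as an at least 5.6-fold lower number from compound 1 to compound 4 (0.75 log units; beyond the scatter), while methoxy in place of hydrogen on a carbonyl carbon alone gives an at least 5.6-fold lower number from compound 3 to compound 4 (0.75 log units; beyond the scatter). These sizes are minimum sizes, not exact ones, because the three other compounds give no number to subtract from: the limit of > 400 ug/mL in this assay, at which 3 of the 4 values shown sit.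

The steps among compound 1, compound 2 and compound 3 still cannot be read. Going by these compounds, it stays open whether ethoxy in place of the methoxy would move the number further, and whether a free amine at this place would return the reading to the limit.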